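Furan to Thiophene on the Saturated Ring Carbon

The source may hold more compounds than are shown below. What is called first, only, known or untested is meant among the compounds shown, and "the series" means these compounds.

Measured compounds:
Compound 1, `CCNC(=O)C1=C(C)NC(=O)NC1c1ccco1`, gives 3%.
Compound 2, `CCNC(=O)C1=C(C)NC(=O)NC1c1ccoc1`, gives 1%.

Both compounds were tested in an assay on membranes from HeLa cells for displacement of a labelled ligand from adenosine receptor A3 (Homo sapiens), read by scintillation counting, with a stated time of 180 min, tested at 1 uM; on this read-out lower numbers stand for less inhibition and higher numbers for more inhibition at the one concentration tested (going by the name of the read-out). On these two numbers compound 2 stands lowest, and its nearest neighbour is compound 1, the two being separated by a step that is a number 2 percentage points lower from compound 1 to compound 2 (within the scatter). That step, the only one measured, changes one furan for another on the saturated ring carbon of the shared core; it does not touch the kind of heteroatom in the five-membered ring.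

Compound 3, `CCNC(=O)C1=C(C)NC(=O)NC1c1cccs1`, has not been measured. Compared with compound 2 the change is thiophen-2-yl in place of furan-3-yl on a saturated ring carbon. For the measured compounds named here, no measured step here swaps an oxygen-containing ring for a sulfur-containing one, so the expectation can rest only on the fact that compound 1 and compound 2 both sit near the bottom of the scale. Going by the values given here, because compound 2 gives 1% and the one known step is a number 2 percentage points lower from compound 1 to compound 2 (within the scatter), the expected step for compound 3 is a number 2 percentage points higher from compound 2 to compound 3 (within the scatter), that is, no change beyond the scatter. The estimate for compound 3 is therefore 3%, with a range from -5% to 12%.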

Compound 3, a percentage reported as inhibition, at one concentration (the size of the read-out at that concentration, not a potency): 4%
For compound 3 the middle estimate is 1 percentage points below the measured one; the measured number falls inside the stated range.
By their numbers in this assay, from the lowest: compounds 2, 1 and 3 (each within the scatter of the next).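

For the compounds shown here, with thiophen-2-yl on the saturated ring carbon, the oxygen of the five-membered aromatic ring gives way to sulfur for the first time, whereas the earlier step only exchanged one furan for another. In this assay, this exchange gives a number 3 percentage points higher from compound 2 to compound 3 (within the scatter) and, measured against the other furan, a number 1 percentage points higher from compound 1 to compound 3 (within the scatter), so neither the attachment point of the furan nor the swap of oxygen for sulfur separates these three compounds on this read-out. All three therefore read alike at the one concentration tested, and no information here explains that sameness.

The compounds shown leave open whether this position can move the number at all when it carries something other than a five-membered aromatic ring with one hetero atom, such as a phenyl ring, a carboxylic acid or an amine on a short carbon chain. They also leave open whether a longer chain in place of the ethyl of the ethylcarbamoyl group, with thiophen-2-yl or either furan kept on the saturated ring carbon, would give a reading distinct from these three.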